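The source may report more compounds than this note shows. Statements on the series, on what has been measured and on what is new or still open speak of the compounds shown alone.

Measured compounds:

- compound 1, `FC(F)(F)c1cccc(-c2nc3cnc(Nc4ccccn4)cc3[nH]2)c1`: 45%
- compound 2, `FC(F)(F)Oc1ccc(-c2nc3cnc(Nc4ccccn4)cc3[nH]2)cc1`: 61%
- compound 3, `COc1ccnc(Nc2cc3[nH]c(-c4cccc(C(F)(F)F)c4)nc3cn2)c1`: 71%

In an ADME assay on microsomes from liver (Rattus norvegicus) for metabolic stability, read by LC-MS, with a stated time of 30 min, tested at 0.1 uM (on this read-out lower numbers stand for a less stable compound and higher numbers for a more stable compound), compound 3 gives the highest of the three numbers. Its nearest neighbour is compound 2, whose number sits within the scatter of compound 3, so the two cannot be ranked against each other. Compound 1 lies furthest away, and the one step that links measured compounds, a number 26 percentage points higher from compound 1 to compound 3 (beyond the scatter), is the only change shown here that is beyond the scatter.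

Compound 4, `FC(F)(F)c1cccc(-c2nc3cnc(Nc4cccnn4)cc3[nH]2)c1`, is not yet measured. It differs from compound 3 by pyridazin-3-yl in place of 4-methoxypyridin-2-yl on a nitrogen on an aromatic ring. This change has two parts: the methoxy group is removed, and the ring it sat on is exchanged for one with a second ring nitrogen. Only the first part has a measured counterpart: the step of a number 26 percentage points higher from compound 1 to compound 3 (beyond the scatter) shows what adding the methoxy did, so removing it is expected to undo a gain of that size. Among the measured compounds shown here, for the ring exchange no measured pair exists, so its contribution is unknown. Compound 4 is therefore expected to fall back toward compound 1 by a step of a number 26 percentage points lower from compound 3 to compound 4 (beyond the scatter) in this assay. The estimate for compound 4 is 45%, with a range from 25% to 65%.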

Compound 4, percent of the compound remaining: 69%
For compound 4 the middle estimate is 24 percentage points below the measured one, and the stated range ends below it.
By their numbers in this assay, from the lowest: compound 1; then compounds 2, 4 and 3 (each within the scatter of the next).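

In this assay the group on the amino nitrogen can take two quite different forms with no order between them: pyridazin-3-yl in place of 4-methoxypyridin-2-yl gives a number 2 percentage points lower from compound 3 to compound 4 (within the scatter) and so the two compounds cannot be ranked. The earlier compounds shown here showed a higher number at this position only with a methoxy added, whereas pyridazin-3-yl in place of pyridin-2-yl gives a number 24 percentage points higher from compound 1 to compound 4 (beyond the scatter) with no methoxy present, a step of much the same size as a number 26 percentage points higher from compound 1 to compound 3 (beyond the scatter) and one that comes with a ring holding 2 hetero atoms instead of 1. At this position the methoxy is therefore not the only change that goes with a higher number, although nothing shown gives a reason for either step.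

The compounds shown leave open whether a methoxy on the pyridazin-3-yl ring would raise the number further, and whether an amine or a carboxylic acid on that ring would keep it. They also leave open whether pyridazin-3-yl gives a similar step when the trifluoromethoxy-bearing ring of compound 2 stands on the other side of the core.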